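Shifting one chlorine from compound 3 to compound 4

A few compounds are considered here, and "the series" means these few. Any claim that something is new, unique, unknown or untested is made for them only; others in the source may bear on it.

Compound 1 `O=C(CSC(=S)N[C@H]1CCOC1=O)Nc1ccc(Br)cc1`: 67400 nM
Compound 2 `O=C(CSC(=S)N[C@H]1CCOC1=O)Nc1ccccc1Cl`: > 128000 nM
Compound 3 `O=C(CCl)Nc1ccc(C(=O)/C=C/c2ccc(Cl)cc2)cc1`: 8340 nM

All three were tested in a functional assay on EC9706 cells (Homo sapiens) for cytotoxicity, read by MTT assay, with a stated time of 72 h; a higher number here means a weaker inhibitor, a lower number a stronger inhibitor. The entry for compound 2 is a limit and not a number. Of the two exact values, compound 3 has the lower, at 8340 nM, while compound 1 gives 67400 nM, a gap beyond the scatter.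

Compound 4 `O=C(CCl)Nc1ccc(C(=O)/C=C/c2ccccc2Cl)cc1` has the same atoms as compound 3, joined differently: 2-chlorophenyl in place of 4-chlorophenyl on a double-bonded chain carbon bound to a double-bonded chain carbon. Going by the values given here, no measured pair isolates this change. Among the compounds with values here, only one measured step bears on it, and only loosely, as it places 2-chlorophenyl in place of 4-bromophenyl on an amide-type nitrogen, with a different core: an at least 1.8-fold higher number from compound 1 to compound 2 (0.27 log units; that floor lies within the scatter). That floor lies within the scatter, so it points only weakly towards a higher number, and a modest rise at most is expected here. The estimated step is a 1.4-fold higher number from compound 3 to compound 4 (0.16 log units; within the scatter). For compound 4 the expected value is 12000 nM, with an estimated range from 4000 nM to 35000 nM.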

Compound 4, half-maximal inhibitory concentration: 6980 nM
Estimate against measurement, compound 4: 1.7-fold (0.24 log units) above; low and high end bracket the measured number.
By their numbers in this assay, from the lowest: compounds 4 and 3 (each within the scatter of the next); then compound 1. At a limit, above all of these: compound 2.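

In this assay, placing 2-chlorophenyl in place of 4-chlorophenyl on a double-bonded chain carbon bound to a double-bonded chain carbon gives a 1.2-fold lower number from compound 3 to compound 4 (0.08 log units; within the scatter) and so separates the two compounds by no more than the usual scatter. The earlier compounds shown here offered only a looser comparison, on an amide-type nitrogen and with a different core, whereas this pair shows that, at this place, the two chlorophenyl groups cannot be told apart in this read-out. Nothing in the data shown explains this result.

As far as these compounds go, what remains open is whether this place would give a similar number with an unsubstituted phenyl or with an amine on the ring. From the compounds shown here alone, it is also open how a carboxylic acid or a longer chain would read there.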